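Moving Two Chlorines Around the Sulfonamide Aryl Ring

A few compounds are considered here, and "the series" means these few. Any claim that something is new, unique, unknown or untested is made for them only; others in the source may bear on it.

Three compounds sharing one core have so far been measured in a functional assay on cells (leukaemia cell line, Homo sapiens) for inhibition, read by sulforhodamine B assay, with a stated time of 48 h; a higher number here means a weaker inhibitor of growth, a lower number a stronger inhibitor of growth:

compound 1 `O=S(=O)(Nc1ccc(Cl)c(Cl)c1)c1ccc(-c2cnc(C3CC3)o2)cc1`: 416 nM
compound 2 `O=S(=O)(Nc1ccc(Cl)cc1Cl)c1ccc(-c2cnc(C3CC3)o2)cc1`: 481 nM
compound 3 `O=S(=O)(Nc1ccc(Cl)c(F)c1)c1ccc(-c2cnc(C3CC3)o2)cc1`: 380 nM

Compound 1 holds the second highest of these three numbers. Its nearest neighbour is compound 3, reached by the step of a 1.1-fold lower number from compound 1 to compound 3 (0.04 log units; within the scatter); its furthest is compound 2, reached by the step of a 1.2-fold higher number from compound 1 to compound 2 (0.06 log units; within the scatter). Both steps, and also a 1.3-fold lower number from compound 2 to compound 3 (0.10 log units; within the scatter), lie within the usual scatter, so these three compounds cannot be told apart on the numbers shown.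

Compound 4 `O=S(=O)(Nc1cc(Cl)ccc1Cl)c1ccc(-c2cnc(C3CC3)o2)cc1` has not yet been measured. It differs from compound 1 only at the aryl ring on the sulfonamide nitrogen: 2,5-dichlorophenyl in place of 3,4-dichlorophenyl on a sulfonamide nitrogen. Among the measured compounds shown here, the steps that bear on this change are the ones that rearrange halogens on that same ring, namely from compound 1 to compound 2 and from compound 2 to compound 3, and neither moved the number beyond the scatter. The expected step is therefore a 1.1-fold higher number from compound 1 to compound 4 (0.03 log units; within the scatter), with no change expected beyond the scatter. Compound 4 is estimated at 450 nM, within a range of 220 nM to 900 nM.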

Compound 4, concentration for 50% growth inhibition: 1020 nM
Estimate against measurement, compound 4: 2.3-fold (0.36 log units) below, and the stated range ends below it.
By their numbers in this assay, from the lowest: compounds 3, 1 and 2 (each within the scatter of the next); then compound 4.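

In this assay, the earlier rearrangements of halogens on the aryl ring did not separate the compounds, but 2,5-dichlorophenyl on the sulfonamide nitrogen gives a step beyond the scatter with the same atoms joined differently (a 2.5-fold higher number from compound 1 to compound 4 (0.39 log units; beyond the scatter)). The other two comparisons agree (a 2.7-fold higher number from compound 3 to compound 4 (0.43 log units; beyond the scatter); a 2.1-fold higher number from compound 2 to compound 4 (0.33 log units; beyond the scatter)), which makes compound 4 the weakest inhibitor of growth of the four, though each step is modest. Nothing available explains why this arrangement of the two chlorines stands apart.

Still open, as far as these compounds go, is whether methoxy or trifluoromethyl groups in place of the two chlorines of the 2,5-dichlorophenyl ring would keep the higher number. Also open, from the compounds shown here alone, is how a plain phenyl ring on the sulfonamide nitrogen compares with all four compounds.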